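Naphthalen-1-yl in place of 4-methoxyphenyl in the series

This account rests on a few compounds, and the source may have more. Where it says the series, first, only, none or still open, it means among the compounds named here.

Within the data shown here, in a functional assay on RS4-11 cells (Homo sapiens) for inhibition, read by CCK-8 assay, with a stated time of 48 h, tested at 20 uM (on this read-out lower numbers stand for less inhibition of growth and higher numbers for more inhibition of growth at the one concentration tested), compound 1 (`COc1ccc(Cc2nnc(NC(=O)/C(C#N)=C/c3ccccc3OS(=O)(=O)c3ccccc3[N+](=O)[O-])s2)cc1`) gives 68%, the lower of the two numbers so far. Compound 2 (`COc1ccc(Cc2nnc(NC(=O)/C(C#N)=C/c3ccccc3OS(=O)(=O)c3ccc(F)cc3)s2)cc1`) gives 80%. That single measured step, a number 12 percentage points higher from compound 1 to compound 2 (beyond the scatter), is modest but beyond the scatter, and it concerns the group on the sulfonyl sulfur, not the group changed here.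

Compound 3 (`N#C/C(=C\c1ccccc1OS(=O)(=O)c1ccccc1[N+](=O)[O-])C(=O)Nc1nnc(Cc2cccc3ccccc23)s1`) keeps the 2-nitrophenyl of compound 1 and carries naphthalen-1-yl in place of 4-methoxyphenyl on a saturated chain carbon bound to an aromatic carbon. Among the measured compounds shown here, no measured step touches this place. The only rough gauge of size is a number 12 percentage points higher from compound 1 to compound 2 (beyond the scatter), so no step beyond the scatter is expected in this assay, and no direction is favoured. The estimated step is a number 2 percentage points higher from compound 1 to compound 3 (within the scatter). For compound 3 the expected value is 70%, with an estimated range of 52% to 86%.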

Compound 3, percent growth inhibition at one concentration: 66%
For compound 3 the middle estimate is 4 percentage points above the measured one; measured number inside the range.
By their numbers in this assay, from the lowest: compounds 3 and 1 (each within the scatter of the next); then compound 2.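

In this assay, naphthalen-1-yl in place of 4-methoxyphenyl on a saturated chain carbon bound to an aromatic carbon gives a number 2 percentage points lower from compound 1 to compound 3 (within the scatter). This place therefore accepts a group with 2 six-membered aromatic rings and no oxygen with no change in growth inhibition beyond the scatter at the one concentration tested, whereas the step from compound 1 to compound 2 spoke only to the group on the sulfonyl sulfur. No measurement shown here bears on why the two groups read alike.

Open, as far as these compounds go, is whether naphthalen-1-yl also reads like 4-methoxyphenyl alongside the 4-fluorophenyl on the sulfonyl sulfur of compound 2. Also open, from the compounds shown here alone, is how a group carrying an amine or a carboxylic acid would read at this place.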